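The compounds below may be only part of what the source reports. "The series", "measured", "known", "first", "only" and "open" are said of these compounds alone.

Measured so far in a functional assay on MDA-MB-231 cells (Homo sapiens) for inhibition, read by WST assay, with a stated time of 48 h; a higher number here means a weaker inhibitor, a lower number a stronger inhibitor:
compound 1 `O=[N+]([O-])c1cccc(/C=N\NC(=S)NC2CCCCC2)c1` gives 84800 nM;
compound 2 `Oc1ccc(/C=N\NC(=S)NC2CCCCC2)c(O)c1` gives 56600 nM.

Compound 1 and compound 2 share the same thiosemicarbazone core and differ only in what the aromatic ring carries. Among the compounds with values here, their two numbers in this assay lie within the usual scatter of each other, so compound 1 is not set apart from compound 2 by the data in hand, and no single-point step between measured compounds is available to lean on.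

Compound 3 `Oc1cccc(/C=N\NC(=S)NC2CCCCC2)c1` is the next case. It differs from compound 1 by hydroxy in place of nitro on an aromatic carbon, a hydroxy in place of nitro on an aromatic carbon. Since compound 2, which also carries hydroxy groups on that ring, gives 56600 nM, no change beyond the scatter is expected from compound 1 to compound 3, and the step of a 1.3-fold lower number from compound 1 to compound 3 (0.12 log units; within the scatter) is estimated accordingly. Compound 3 is therefore expected to give about 65000 nM in this assay, in a range from 25000 nM to 170000 nM.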

Compound 3, half-maximal inhibitory concentration: 24500 nM
The estimate for compound 3 lay 2.7-fold (0.42 log units) above the measured number, and the stated range ends above it.
By their numbers in this assay, from the lowest: compound 3; then compounds 2 and 1 (each within the scatter of the next).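

In this assay, hydroxy in place of nitro on an aromatic carbon, meta to a large group, gives a 3.5-fold lower number from compound 1 to compound 3 (0.54 log units; beyond the scatter), the first step among these compounds and one that lies beyond the scatter. This shows that the group at this place on the ring matters in this assay, and that the change leads toward a stronger inhibitor, although the step is modest and rests on a single pair. Nothing at hand explains why this change lowers the number.

The compounds shown leave open whether an amine or a methoxy on the same carbon would give a number closer to that of compound 3 or to that of compound 1, and so whether the step belongs to the hydroxy that enters or the nitro that leaves. They also leave open whether the same change would give a step of similar size on a different core.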